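A few compounds are considered here, and "the series" means these few. Any claim that something is new, unique, unknown or untested is made for them only; others in the source may bear on it.

Measured in an assay on isolated protein for inhibition of histone deacetylase HD1B (Zea mays); a higher number here means a weaker inhibitor, a lower number a stronger inhibitor: compound 1 `Cn1cc(/C=C/C(=O)c2ccccc2)cc1/C=C/C(=O)NO` gives 260 nM. Compound 2 `Cn1cc(/C=C/C(=O)c2ccc(F)cc2)cc1/C=C/C(=O)NO` gives 24900 nM. Compound 3 `COc1cccc(C(=O)/C=C/c2cc(/C=C/C(=O)NO)n(C)c2)c1` gives 600 nM.

Compound 3 stands second highest of the three numbers. Nearest neighbour: a 2.3-fold higher number from compound 1 to compound 3 (0.36 log units; beyond the scatter). Furthest: a 42-fold lower number from compound 2 to compound 3 (1.62 log units; beyond the scatter).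

Compound 4 `Cn1cc(/C=C/C(=O)c2ccco2)cc1/C=C/C(=O)NO` differs from compound 3 by furan-2-yl in place of 3-methoxyphenyl on a carbonyl carbon. Among the measured compounds shown here, the one step that bears on this directly is the other swap of the group on the carbonyl carbon, a 42-fold lower number from compound 2 to compound 3 (1.62 log units; beyond the scatter), which was large; together with a 96-fold higher number from compound 1 to compound 2 (1.98 log units; beyond the scatter) and a 2.3-fold higher number from compound 1 to compound 3 (0.36 log units; beyond the scatter) it shows this region of the core moves the number widely. No furan has been measured, so the direction is open. A step of modest size, a 1.2-fold higher number from compound 3 to compound 4 (0.07 log units; within the scatter), is expected. Compound 4 is estimated at 700 nM, range 150 nM to 5000 nM.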

Compound 4, half-maximal inhibitory concentration: 19700 nM
Beside the measured number, compound 4's estimate is 28-fold (1.45 log units) below it; the whole stated range lies below it.
By their numbers in this assay, from the lowest: compound 1; then compound 3; then compounds 4 and 2 (each within the scatter of the next).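

In this assay, furan-2-yl on the carbonyl carbon gives a large loss against both six-membered aromatic groups without fluoro (a 33-fold higher number from compound 3 to compound 4 (1.52 log units; beyond the scatter); a 76-fold higher number from compound 1 to compound 4 (1.88 log units; beyond the scatter)), and it lands level with 4-fluorophenyl (a 1.3-fold lower number from compound 2 to compound 4 (0.10 log units; within the scatter)). The weak level is therefore not peculiar to compound 2, and among these four compounds only phenyl and 3-methoxyphenyl keep the number low. Nothing available explains this split.

Open, as far as these compounds go, is whether thiophene or pyridine on the carbonyl carbon stays at the weak level or returns to the low one. Also open, from the compounds shown here alone, is whether 4-chlorophenyl or 4-methoxyphenyl tracks compound 2 or compound 3.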